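This account rests on a few compounds, and the source may have more. Where it says the series, first, only, none or still open, it means among the compounds named here.

Measured so far in the series:
compound 1, `COc1cc(/C=N/NC(=S)NC(C)(C)[C@H]2CC=C(C)CC2)ccc1O`: > 100000 nM
compound 2, `CC1=CC[C@H](C(C)(C)NC(=S)N/N=C/c2cccs2)CC1`: 35100 nM
compound 3, `CC1=CC[C@H](C(C)(C)NC(=S)N/N=C(\C)c2ccccc2)CC1`: > 100000 nM

In a functional assay on OVCAR-3 cells (Homo sapiens) for inhibition, read by sulforhodamine B assay, with a stated time of 48 h (a higher number here means a weaker inhibitor of growth, a lower number a stronger inhibitor of growth), compound 1 gives > 100000 nM, which is a limit of the assay and not a number. In this assay, within the data shown here, compound 2 gives 35100 nM, the only numeric value so far. Compound 3 gives > 100000 nM in this assay, again a limit and not a number. Compound 3 therefore stands at the limit of > 100000 nM in this assay, at which 2 of the 3 values shown sit, and nothing places it relative to compound 1 beyond that shared limit; only compound 2 falls below it.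

The next compound, compound 4, `CC1=CC[C@H](C(C)(C)NC(=S)N/N=C(\C)c2ccc([N+](=O)[O-])cc2)CC1`, differs from compound 3 by nitro in place of hydrogen on an aromatic carbon. Among the measured compounds shown here, no measured step between compounds shows what such a change does here. With compound 3 at the limit, the expected step in this assay is none that can be resolved beyond the scatter, with the possibility of a modest gain at best. Compound 4 is expected to give about 80000 nM in this assay, within 20000 nM to 300000 nM, which means a step from compound 3 to compound 4 of an at least 1.2-fold lower number from compound 3 to compound 4 (0.09 log units; that floor lies within the scatter), and compound 4 may well be expected to sit at a limit as well.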

Compound 4, concentration for total growth inhibition: 29300 nM
For compound 4 the middle estimate is 2.7-fold (0.44 log units) above the measured one, within the range that was stated.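

In this assay, nitro in place of hydrogen on an aromatic carbon, para to a large group, gives an at least 3.4-fold lower number from compound 3 to compound 4 (0.53 log units; beyond the scatter). Among these compounds, this is the first step between compounds that differ in one place, and it shows that a substituent at this position of the six-membered aromatic ring can move the read-out, which compounds 1 to 3 could not show. Compound 3 carries a limit and not a number, so only the floor of this step is known: the limit of > 100000 nM in this assay, at which 2 of the 4 values shown sit.

From the compounds shown here alone, whether the gain is specific to nitro stays open, and an amine or a nitrile at the same place would test that. Also open, going by these compounds, is whether nitro would give a similar step on the aromatic rings of compound 1 or compound 2.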